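The source may hold more compounds than are shown below. What is called first, only, known or untested is meant among the compounds shown, and "the series" means these compounds.

Compound 2, with the structure `Clc1ccc(-c2cn3ccnc3c(-c3ccc4ncn(C5CCCCC5)c4c3)n2)cc1`, gives 10.9% in a functional assay on SK-MEL-2 cells (Homo sapiens) for inhibition, read by sulforhodamine B assay, with a stated time of 48 h, tested at 10 uM; on this read-out higher numbers stand for more inhibition at the one concentration tested (going by the name of the read-out) and lower numbers for less inhibition. Among the compounds with values here, that is the lower of the two numbers so far, and its nearest neighbour is compound 1, whose structure is `c1ccc(-c2cn3ccnc3c(-c3ccc4ncn(C5CCCCC5)c4c3)n2)cc1` and which gives 16.5% in this assay; the step of a number 5.6 percentage points lower from compound 1 to compound 2 (within the scatter) is within the scatter. Compound 3, with the structure `Brc1ccc(-c2cn3ccnc3c(-c3ccc4ncn(C5CCCCC5)c4c3)n2)cc1`, has not yet been measured. It differs from compound 2 in one place: bromo in place of chloro on an aromatic carbon. Within the data shown here, only one measured step bears on this, the replacement of hydrogen by chloro going from compound 1 to compound 2, and that step was small, so the size of an exchange of one halogen for another on the same aromatic carbon is unknown here. No step beyond the scatter is therefore expected in this assay. Compound 3 is estimated to give 12% in this assay, in a range from 0% to 30%. This estimate means an expected step of a number 1.1 percentage points higher from compound 2 to compound 3 (within the scatter) within the scatter.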

Compound 3, a percentage reported as inhibition, at one concentration (the size of the read-out at that concentration, not a potency): 24.1%
The estimate for compound 3 lay 12.1 percentage points below the measured number; the range from low to high includes it.
By their numbers in this assay, from the lowest: compounds 2, 1 and 3 (each within the scatter of the next, the first and the last beyond it).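

Within the data shown here, on an aromatic carbon of this six-membered aromatic ring of carbon only, para to a large group, the choice of halogen now registers in this assay: the exchange of chloro for bromo gives the only step beyond the scatter (a number 13.2 percentage points higher from compound 2 to compound 3 (beyond the scatter)), and it is a modest one. Hydrogen cannot be told apart from either halogen, as the step to the bromo compound (a number 7.6 percentage points higher from compound 1 to compound 3 (within the scatter)) is within the scatter, like the earlier step to the chloro compound, so the two halogens differ from each other without either being set apart from hydrogen. Nothing available here accounts for the gap between chloro and bromo.

From the compounds shown here alone, whether fluoro or iodo at this carbon would extend the difference between the halogens remains open. So does the outcome with a non-halogen group there, such as methyl, methoxy or nitrile.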